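The compounds below may be only part of what the source reports. "The series", "measured", "known", "first", "only" and "open" are said of these compounds alone.

Of the compounds shown here, three have been measured so far. Compound 1 `CC[C@@H]1CN(c2scnc2-c2nc3ccccc3[nH]2)CCN1C(=O)Cn1cnc2cccnc21` gives 604 nM in a functional assay on U2OS cells for antagonist activity at C-X-C chemokine receptor type 3 (Homo sapiens), read by beta-arrestin recruitment; on this read-out higher numbers stand for weaker inhibition and lower numbers for stronger inhibition. Compound 2 `COc1ccc(-c2nc(C(F)(F)F)sc2N2CCN(C(=O)Cn3cnc4cccnc43)[C@H](C)C2)cc1` gives 131 nM in this assay, and compound 3 `CCOc1ncc(-c2nc(C(F)(F)F)sc2N2CCN(C(=O)Cn3ncc4cccnc43)[C@H](C)C2)cn1` gives 55 nM. Compound 3 therefore has the lowest number of the three, that is, the strongest inhibition: its gap to compound 2 lies beyond the scatter of repeated measurements, and its gap to compound 1 is wider still.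

The next compound, compound 4 `CCOc1ncc(-c2nc(C(F)(F)F)sc2N2CCN(C(=O)Cn3ccc(C(F)(F)F)n3)[C@H](C)C2)cn1`, keeps the core of compound 3 and changes only one end of the molecule: a group of 9 heavy atoms (4 carbon, 2 nitrogen, 3 fluorine; one five-membered aromatic ring with 2 hetero atoms) in place of a group of 9 heavy atoms (6 carbon, 3 nitrogen; one five-membered aromatic ring with 2 hetero atoms, one six-membered aromatic ring with 1 hetero atom), on a saturated chain carbon bound to a carbonyl carbon. Among the compounds with values here, no pair of measured compounds shows this kind of exchange, so there is no measured step to lean on, and the size of the change can only be estimated. The group that leaves is a fused two-ring system, and the group that enters is a single ring with a trifluoromethyl group. A modest loss of inhibition is expected rather than none. The expected step of a 2.7-fold higher number from compound 3 to compound 4 (0.44 log units; beyond the scatter) points toward a higher number. Compound 4 is accordingly expected to give about 150 nM in this assay, within a range from 40 nM to 600 nM.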

Compound 4, half-maximal inhibitory concentration: 93 nM
Compound 4: the middle estimate sits 1.6-fold (0.21 log units) above what was measured; low and high end bracket the measured number.
By their numbers in this assay, from the lowest: compounds 3, 4 and 2 (each within the scatter of the next, the first and the last beyond it); then compound 1.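

In this assay, replacing the fused two-ring group with 3-(trifluoromethyl)-1H-pyrazol-1-yl, on a saturated chain carbon bound to a carbonyl carbon, gives a 1.7-fold higher number from compound 3 to compound 4 (0.23 log units; within the scatter). For this pair, then, the six-membered aromatic ring of the leaving group is not needed to hold inhibition: a single five-membered aromatic ring carrying trifluoromethyl, with the same count of heavy atoms, does as well within the scatter. No measured property is available to explain this result.

The compounds shown leave open how much the trifluoromethyl group itself contributes, since this ring does not appear here with a methyl group, a nitrile or a chlorine in its place. On these data alone, it also remains open whether the exchange would give a similar result on the cores of compound 1 or compound 2.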